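Glycine for Alanine in a Nitroimidazole-Linked Salicylate Ester

The source may report more compounds than this note shows. Statements on the series, on what has been measured and on what is new or still open speak of the compounds shown alone.

Measured so far:
Compound 1, `CC(=O)Nc1ccc(O)c(C(=O)O)c1`, gives 0% in a functional assay on the whole organism (strain Wistar) for inhibition, with Rattus norvegicus as the target, read by paw edema, with stated times of 1 h and 24 h, at a dose of 10 mg/kg by the intraperitoneal route; on this read-out lower numbers stand for less inhibition and higher numbers for more inhibition at the one dose given (going by the name of the read-out).
Compound 2, `Cc1ncc([N+](=O)[O-])n1CCOC(=O)c1cc(NC(=O)[C@H](C)NC(=O)OCc2ccccc2)ccc1O`, gives 11.6% in this assay.

Of the two numbers in hand, compound 2 stands highest. Going by the values given here, its only neighbour is compound 1, whose value lies lower by a margin that is beyond the usual scatter of this kind of measurement; the two values therefore show a real gap, although no single structural step links them, and nothing more is said about why they differ.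

Compound 3, `Cc1ncc([N+](=O)[O-])n1CCOC(=O)c1cc(NC(=O)CNC(=O)OCc2ccccc2)ccc1O`, is the next candidate and is not yet measured. It keeps the whole of compound 2 except at one point, and the change is hydrogen in place of methyl on a saturated chain carbon bound to an amide-type nitrogen and a carbonyl carbon. Among the compounds with values here, no step between measured compounds covers a change of this sort, so there is no direct precedent for its size. A single carbon lost from a saturated chain carbon of this kind is a small alteration, and no step beyond the scatter is expected in this assay in either direction. In that assay compound 3 is expected to give about 10%, with a range from 0% to 25%. The estimated step of a number 1.6 percentage points lower from compound 2 to compound 3 (within the scatter) is expected to remain within the usual scatter.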

Compound 3, a percentage reported as inhibition, in the whole organism at one dose (the size of the read-out at that dose, not a potency): 17.1%
Compound 3: middle estimate off by 7.1 percentage points, on the low side, within the range that was stated.
By their numbers in this assay, from the lowest: compound 1; then compounds 2 and 3 (each within the scatter of the next).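

In this assay, going by these compounds alone, the exchange of methyl for hydrogen on the saturated chain carbon bound to an amide-type nitrogen and a carbonyl carbon gives the first direct reading at this position, with a number 5.5 percentage points higher from compound 2 to compound 3 (within the scatter). At the one dose given, this read-out therefore does not separate the compound that carries the methyl from the one that carries only hydrogen, so the methyl shows no measurable part in the response. No measurement in hand bears on why the two values fall as they do, and no explanation of the step can be offered.

With only hydrogen and methyl shown on this carbon, the compounds leave open whether a larger group, such as isopropyl or benzyl, or a chain ending in an amine or a carboxylic acid, would move the response beyond the usual scatter. They also leave open what the methyl would do on the opposite side of this carbon, since compound 2 shows only one of the two mirror-image arrangements.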